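Working notes: open-chain acid amide in place of aryl group

The compounds below may be only part of what the source reports. "The series", "measured", "known", "first", "only" and "open" are said of these compounds alone.

Measured in a functional assay on Ehrlich cells (Mus musculus) for cytotoxicity, read by trypan blue exclusion, with a stated time of 2 h, tested at 10 ug/mL; on this read-out higher numbers stand for a stronger effect at the one concentration tested and lower numbers for a weaker effect:
compound 1 `CCCCNC(=S)NC1=C(C#N)C(c2ccc(Cl)cc2Cl)C2=C(CCCC2=O)N1c1ccc(S(N)(=O)=O)cc1` gives 30%;
compound 2 `N#CC1=C(NC(=S)Nc2ccc(Cl)cc2)N(c2ccc(S(N)(=O)=O)cc2)C2=C(C(=O)CCC2)C1c1ccc(Cl)cc1Cl` gives 30%;
compound 3 `N#CC1=C(NC(=S)Nc2ccc(Br)cc2)N(c2ccc(S(N)(=O)=O)cc2)C2=C(C(=O)CCC2)C1c1ccc(Cl)cc1Cl` gives 50%.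

Compound 3 stands highest of the three numbers in this assay: the steps of a number 20 percentage points higher from compound 1 to compound 3 (beyond the scatter) and a number 20 percentage points higher from compound 2 to compound 3 (beyond the scatter) both lie beyond the scatter, whereas no change at the digits printed from compound 1 to compound 2 (within the scatter) does not. Compound 4 `N#CC1=C(NC(=O)CCC(=O)O)N(c2ccc(S(N)(=O)=O)cc2)C2=C(C(=O)CCC2)C1c1ccc(Cl)cc1Cl` is not yet measured. Its difference from compound 3 is a group of 7 heavy atoms (4 carbon, 3 oxygen; no ring) in place of a group of 10 heavy atoms (7 carbon, 1 nitrogen, 1 sulfur, 1 bromine; one six-membered aromatic ring of carbon only), on an amine nitrogen.

Going by the values given here, no measured step exchanges the group on the amine nitrogen for an open-chain carbonyl group. The steps that touch this position, no change at the digits printed from compound 1 to compound 2 (within the scatter) and a number 20 percentage points higher from compound 1 to compound 3 (beyond the scatter), replace butyl by an aryl group and show at most a modest rise. The bromo group that sets compound 3 apart in a number 20 percentage points higher from compound 2 to compound 3 (beyond the scatter) leaves in compound 4, and nothing in the measured compounds points to a gain from the entering (2-carboxyethyl)carbonyl group. A downward step of about a number 25 percentage points lower from compound 3 to compound 4 (beyond the scatter) is therefore expected. Compound 4 is expected to give 25%, with a range from 10% to 45%.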

Compound 4, a percentage reported as activity, at one concentration (the size of the read-out at that concentration, not a potency): 20%
Compound 4: the middle estimate sits 5 percentage points above what was measured, and the stated range covers the measured number.
By their numbers in this assay, from the lowest: compounds 4, 1 and 2 (each within the scatter of the next); then compound 3.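

In this assay, the (2-carboxyethyl)carbonyl group on an amine nitrogen cannot be told apart from the butyl-bearing and 4-chlorophenyl-bearing groups, with a number 10 percentage points lower from compound 1 to compound 4 (within the scatter) and a number 10 percentage points lower from compound 2 to compound 4 (within the scatter). The exchange registers only against the 4-bromophenyl-bearing group, with a number 30 percentage points lower from compound 3 to compound 4 (beyond the scatter), so this position accepts an open-chain carbonyl group with no ring at the level of the chloro and butyl members, while compound 3 remains the strongest of the four. Nothing measured here accounts for these differences.

As far as these compounds go, it remains open whether the terminal carboxylic acid contributes at all, which a methyl ester or a primary amide in its place would test. A longer chain between the two carbonyl groups, or a chain ending in an amine, is also unaddressed by the compounds shown.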